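A fluoro on the ethoxy chain of compound 1

The source may report more compounds than this note shows. Statements on the series, on what has been measured and on what is new or still open speak of the compounds shown alone.

Measured in an ADME assay; a higher number here means that the compound lasts longer, a lower number that the compound disappears faster:
compound 1 `CCOc1cc(OC)ccc1C[S+]([O-])c1ncccc1C(=O)Nc1ccncc1`: < 0.02 h (a limit)
compound 2 `CCOc1ccc(C[S+]([O-])c2ncccc2C(=O)Nc2ccncc2)c(OCC)c1`: < 0.02 h (a limit)

In this assay compound 1 gives < 0.02 h, which is a limit of the assay and not a number. The whole record so far is the limit of < 0.02 h in this assay, at which 2 of the 2 values shown sit.

Compound 3 `COc1ccc(C[S+]([O-])c2ncccc2C(=O)Nc2ccncc2)c(OCCF)c1` alters compound 1 in one place: fluoro in place of hydrogen on a saturated chain carbon, two bonds along the chain from an oxygen on an aromatic ring. This is fluoro in place of hydrogen on a saturated chain carbon, two bonds along the chain from an oxygen on an aromatic ring, or ethoxy to 2-fluoroethoxy.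

For the measured compounds named here, the one measured step that bears on this is a step that the two limits leave unreadable from compound 1 to compound 2, which puts methyl in place of hydrogen on a saturated chain carbon bound to an oxygen on an aromatic ring. Its size cannot be read, so it offers no size or direction to carry over. Compound 3 is therefore expected to stay close to the same limit, and no step beyond the scatter is expected. The step expected here is a step that the limit leaves unreadable from compound 1 to compound 3. For compound 3 the estimate is 0.015 h, with an expected range from 0.008 h to 0.04 h.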

Compound 3, half-life: < 0.02 h
Compound 3 gave a limit, no number; the forecaster's own chance of this, stated with the estimate: 85%; the middle value is on the limit's open side.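

In this assay compound 3 gives < 0.02 h, which is a limit of the assay and not a number. Compound 1 also stands at a limit, so no step can be read from compound 1 to compound 3. The compounds shown leave open how long any of them lasts and whether 2-fluoroethoxy in place of ethoxy changes this. The record remains a single limit: the limit of < 0.02 h in this assay, at which 3 of the 3 values shown sit.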